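Swapping a Thioether for an Ether on the Shared Core

The source may hold more compounds than are shown below. What is called first, only, known or untested is meant among the compounds shown, and "the series" means these compounds.

Going by the values given here, compound 2 `Nc1cc(N)c2nc(-c3ccccc3)c(Sc3ccc(Cl)c(Cl)c3)nc2c1` is the one compound with a number here: in a functional assay on SF-295 cells (Homo sapiens) for inhibition, read by sulforhodamine B assay, with a stated time of 48 h (on this read-out higher numbers stand for weaker inhibition of growth and lower numbers for stronger inhibition of growth), compound 2 gives 17800 nM. Compound 1 `COc1ccc(Sc2nc3cc(N)cc(N)c3nc2-c2ccccc2)cc1` reached only a limit in this assay, namely < 100000 nM. The step that the limit leaves unreadable from compound 1 to compound 2 is therefore unreadable, since it rests on (the limit of < 100000 nM in this assay, at which 1 of the 2 values shown sits). Compound 3 `Nc1cc(N)c2nc(-c3ccccc3)c(Oc3ccc(F)cc3)nc2c1` differs from compound 2 by 4-fluorophenoxy in place of (3,4-dichlorophenyl)sulfanyl on an aromatic carbon. Among the compounds with values here, no measured step covers a sulfur-to-oxygen exchange, so this assay offers no guide to a shift beyond the scatter. Compound 3 is estimated at 25000 nM, with a range from 7000 nM to 100000 nM. The estimated step of a 1.4-fold higher number from compound 2 to compound 3 (0.15 log units; within the scatter) is expected to stay within the scatter.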

Compound 3, concentration for 50% growth inhibition: 20400 nM
Beside the measured number, compound 3's estimate is 1.2-fold (0.09 log units) above it; low and high end bracket the measured number.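

In this assay, going by these compounds alone, exchanging the whole group at this aromatic carbon gives a 1.1-fold higher number from compound 2 to compound 3 (0.06 log units; within the scatter), the first readable step here. The swap of (3,4-dichlorophenyl)sulfanyl for 4-fluorophenoxy therefore changes the linking atom and the ring substituents together, yet the result stays within the usual scatter. Compound 1 holds a limit, so the steps from it cannot be read: the limit of < 100000 nM in this assay, at which 1 of the 3 values shown sits.

The compounds shown leave open whether a group without an aromatic ring at this carbon, such as an amine or a longer alkyl chain, would give a similar result. They also leave open what exchanging sulfur for oxygen does alone, with the ring substituents kept the same.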